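This account rests on a few compounds, and the source may have more. Where it says the series, first, only, none or still open, it means among the compounds named here.

Measured in a functional assay on Ramos cells (Homo sapiens) for antiproliferative activity, read by CCK-8 assay, with a stated time of 48 h; a higher number here means a weaker inhibitor, a lower number a stronger inhibitor:
- Compound 1 `C=CC(=O)N1CCC[C@@H](n2nc(C#CCOc3ccccc3)c3c(N)ncnc32)C1`: 8910 nM
- Compound 2 `C=CC(=O)N1CCC[C@@H](n2nc(C#CCCc3ccccc3)c3c(N)ncnc32)C1`: > 40000 nM (a limit, not a number)
- Compound 3 `C=CC(=O)N1CCC[C@@H](n2nc(C#CCNc3ccccc3)c3c(N)ncnc32)C1`: 18200 nM

Compound 2 has no number of its own, only (the limit of > 40000 nM in this assay, at which 1 of the 3 values shown sits). Compound 4 `C=CC(=O)N1CCC[C@@H](n2nc(C#CCOc3cccc(Cl)c3)c3c(N)ncnc32)C1` departs from it by 3-chlorophenoxy in place of benzyl on a saturated chain carbon bound to a triple-bonded carbon.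

Within the data shown here, two measured steps bear on this change. The first, read backward, is an at least 4.4-fold higher number from compound 1 to compound 2 (0.65 log units; beyond the scatter), which swaps phenoxy for benzyl. The second is an at least 2.1-fold lower number from compound 2 to compound 3 (0.34 log units; beyond the scatter), which replaces benzyl with anilino. Both put the benzyl compound at the weak end, so leaving benzyl should lower the number. Among the measured compounds shown here, no measured compound carries the chlorine, so its contribution remains open and widens the range. The expected change is an at least 5.7-fold lower number from compound 2 to compound 4 (0.75 log units; beyond the scatter), a lower number beyond the scatter. For compound 4 the estimated value is 7000 nM, with an expected range from 2500 nM to 20000 nM.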

Compound 4, half-maximal inhibitory concentration: > 40000 nM
Compound 4 was reported as a limit; the forecaster's own chance of this, stated with the estimate: 5%; at least 5.7-fold (0.75 log units) between middle value and limit.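

In this assay, adding one chlorine to the phenoxy group is enough to weaken the compound, as chloro in place of hydrogen on an aromatic carbon gives an at least 4.4-fold higher number from compound 1 to compound 4 (0.65 log units; beyond the scatter). The 3-chlorophenoxy group also falls behind anilino at this saturated chain carbon bound to a triple-bonded carbon, with an at least 2.1-fold higher number from compound 3 to compound 4 (0.34 log units; beyond the scatter), so the phenoxy oxygen alone does not secure the better values seen with compound 1. The step from compound 2 to compound 4 cannot be read, because both compounds rest on the same limit and not on a number: the limit of > 40000 nM in this assay, at which 2 of the 4 values shown sit.

From the compounds shown here alone, whether the weakening belongs to chlorine as such or to its place on the ring stays open. Going by these compounds, it is also open whether fluorine or methoxy in place of that chlorine would behave the same way.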